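A few compounds are considered here, and "the series" means these few. Any claim that something is new, unique, unknown or untested is made for them only; others in the source may bear on it.

Measured in an in vivo ADME assay on the whole organism (plasma, strain Sprague-Dawley) for pharmacokinetics, with Rattus norvegicus as the target, read by LC-MS, at a dose of 10 mg/kg by the oral route; on this read-out higher numbers stand for higher oral bioavailability and lower numbers for lower oral bioavailability:
- compound 1 `CC(C)(C)c1cc(NC(=O)Nc2ccc(NC(=O)c3ccc(OC4CCN(C5CC5)CC4)cn3)cc2)no1`: 36%
- compound 2 `CC1(C)CC(Oc2ccc(C(=O)Nc3ccc(NC(=O)Nc4cc(C(C)(C)C)on4)cc3)nc2)CC(C)(C)N1`: 8%
- compound 3 `CCN1CCC(Cc2ccc(C(=O)Nc3ccc(NC(=O)Nc4cc(C(C)(C)C)on4)cc3)nc2)CC1`: 12%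

Compound 3, at 12%, sits close to compound 2, with a number 4 percentage points higher from compound 2 to compound 3 (within the scatter). Both lie well under compound 1.

The next compound is compound 4 `CC(C)N1CCC(Oc2ccc(C(=O)Nc3ccc(NC(=O)Nc4cc(C(C)(C)C)on4)cc3)nc2)CC1`, which carries (1-isopropylpiperidin-4-yl)oxy in place of (1-ethylpiperidin-4-yl)methyl on an aromatic carbon. The closest guide is a number 24 percentage points lower from compound 1 to compound 3 (beyond the scatter), where (1-ethylpiperidin-4-yl)methyl replaced (1-cyclopropylpiperidin-4-yl)oxy. The present change runs the other way, so a rise is expected. Its full size is not assured, as a number 28 percentage points lower from compound 1 to compound 2 (beyond the scatter) shows that a piperidinyl group on an oxygen can also go with a low number. The data hold no direct comparison of isopropyl with cyclopropyl on the nitrogen, so the expectation is for a smaller rise than the full reverse of that step.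

The expected change is a number 14 percentage points higher from compound 3 to compound 4 (beyond the scatter).

Compound 4 is estimated at 26%, with an expected range from 10% to 44%.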

Compound 4, oral bioavailability: 17.5%
Compound 4: middle estimate off by 8.5 percentage points, on the high side, within the range that was stated.
By their numbers in this assay, from the lowest: compounds 2, 3 and 4 (each within the scatter of the next); then compound 1.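

In this assay, (1-isopropylpiperidin-4-yl)oxy on the aromatic carbon cannot be told apart from (1-ethylpiperidin-4-yl)methyl, with a number 5.5 percentage points higher from compound 3 to compound 4 (within the scatter), so an oxygen at this position does not by itself go with a higher number. It also cannot be told apart from the hindered group on oxygen, with a number 9.5 percentage points higher from compound 2 to compound 4 (within the scatter), which leaves three compounds together. For the compounds shown here, the one step beyond the scatter here is a number 18.5 percentage points lower from compound 1 to compound 4 (beyond the scatter), where isopropyl replaces cyclopropyl on the ring nitrogen, and compound 1 alone stands apart.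

Going by these compounds, it remains open whether a methyl or a cyclobutyl on that nitrogen would stay with compound 1 or with compound 4, and whether cyclopropyl would hold its number with a carbon link in place of the oxygen. Nothing in the data shown explains the gap between isopropyl and cyclopropyl.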